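Dimethylamino replaces trifluoromethyl in compound 3

The source may report more compounds than this note shows. Statements on the series, on what has been measured and on what is new or still open speak of the compounds shown alone.

Compound 1 `FC(F)(F)c1ccc(-c2ccc(-c3ccc(-c4nc5ccccc5[nH]4)cc3)cc2)cc1`: 48300 nM
Compound 2 `Oc1cccc2[nH]c(-c3ccc(-c4ccc(-c5ccc(C(F)(F)F)cc5)cc4)cc3)nc12`: 5110 nM
Compound 3 `CN(C)c1ccc(-c2ccc(-c3ccc(-c4nc5c(O)cccc5[nH]4)cc3)cc2)cc1`: not yet measured

In a functional assay on ZR-75-1 cells (Homo sapiens) for inhibition, read by sulforhodamine B assay (on this read-out higher numbers stand for weaker inhibition of growth and lower numbers for stronger inhibition of growth), compound 2 holds the lower of the two numbers, 5110 nM, against compound 1 at 48300 nM. Compound 3 keeps the hydroxy but carries dimethylamino in place of trifluoromethyl on an aromatic carbon. For the measured compounds named here, the only measured step, a 9.5-fold lower number from compound 1 to compound 2 (0.98 log units; beyond the scatter), was modest and came from hydroxy in place of hydrogen, so it shows the size one change can reach but gives no direction for this one. A step of similar or smaller size is expected, with its direction uncertain. The estimated step is a 1.3-fold lower number from compound 2 to compound 3 (0.11 log units; within the scatter). For compound 3 the expected value is 4000 nM, within an estimated range of 800 nM to 20000 nM.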

Compound 3, concentration for 50% growth inhibition: 4100 nM
The estimate for compound 3 lay 1.0-fold (0.01 log units) below the measured number; the range from low to high includes it.
By their numbers in this assay, from the lowest: compounds 3 and 2 (each within the scatter of the next); then compound 1.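

In this assay, going from 4-(trifluoromethyl)phenyl to 4-(dimethylamino)phenyl gives a 1.2-fold lower number from compound 2 to compound 3 (0.10 log units; within the scatter), so this position accepts either group with the hydroxy in place. For the compounds shown here, the earlier compounds showed only that the hydroxy step could move the number; this change, unlike that one, cannot be told from the scatter. Nothing available here accounts for the two groups reading alike.

As far as these compounds go, it remains open whether a carboxylic acid, a primary amine or a methoxy group at this position would read differently. From the compounds shown here alone, it is also open whether the same exchange would read alike without the hydroxy.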